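The compounds below may be only part of what the source reports. "The series", "measured", "known", "first", "only" and "open" are said of these compounds alone.

Measured so far in an ADME assay on MDCK cells (Canis lupus familiaris) for cytotoxicity, read by MTT assay, with a stated time of 24 h; a higher number here means that more compound is tolerated, a lower number that less compound is tolerated: compound 1 `N#CCCN(Cc1cccs1)S(=O)(=O)c1ccc(Br)cc1`, compound 2 `Cc1ccc(S(=O)(=O)N(CCC#N)Cc2cccs2)cc1`, compound 3 `N#CCCN(Cc1ccco1)S(=O)(=O)c1ccc(Br)cc1`. Not yet measured: compound 4 `Cc1ccc(S(=O)(=O)N(CCC#N)Cc2ccco2)cc1`.

For compound 1 this assay reports only a limit, > 173000 nM. Compound 2 gives 127000 nM in this assay. For compound 3 the assay again reports only a limit, > 180000 nM. The change methyl in place of bromo on an aromatic carbon gives the step of an at least 1.3-fold lower number from compound 1 to compound 2 (0.13 log units; that floor lies within the scatter), whose floor lies within the scatter. The two cores differ by furan-2-yl in place of thiophen-2-yl on a saturated chain carbon bound to a sulfonamide nitrogen; the step that the two limits leave unreadable from compound 1 to compound 3 is left unreadable by the two limits, compound 1 sitting at the limit of > 173000 nM in this assay, at which 1 of the 3 values shown sits, and compound 3 at the limit of > 180000 nM in this assay, at which 1 of the 3 values shown sits.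

Compound 4 carries the same change, (methyl in place of bromo on an aromatic carbon), on the core of compound 3. The step of an at least 1.2-fold lower number from compound 3 to compound 4 (0.10 log units; that floor lies within the scatter) is expected to be small, resting on an at least 1.3-fold lower number from compound 1 to compound 2 (0.13 log units; that floor lies within the scatter), which reads as at most a modest shift. For compound 4 the estimate in this assay is 140000 nM, expected to fall between 60000 nM and 300000 nM, with a real chance that only a limit is reported.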

Compound 4, half-maximal cytotoxic concentration: > 219000 nM
Compound 4: only a limit was reported; the forecaster's own chance of this, stated with the estimate: 40%; at least 1.5-fold (0.19 log units) between middle value and limit.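

In this assay compound 4 gives > 219000 nM, which is a limit and not a number. Compound 3 is likewise reported only as a limit, so the steps that end on two limits cannot be read, and the series neither confirms nor contradicts that methyl in place of bromo carries over from the core of compound 1 to the core of compound 3. Among the compounds shown here, the only readable new step is an at least 1.7-fold higher number from compound 2 to compound 4 (0.23 log units; that floor lies within the scatter), and it belongs to furan-2-yl in place of thiophen-2-yl, not to the methyl for bromo change.

Left open is how an amine or a carboxylic acid on that aromatic carbon would read in this assay. Also open, as far as these compounds go, is whether the true values of compound 3 and compound 4 differ at all.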